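The source may hold more compounds than are shown below. What is called first, only, known or untested is meant among the compounds shown, and "the series" means these compounds.

In a functional assay on KB 3-1 cells (Homo sapiens) for cytotoxicity, read by MTT assay, with a stated time of 68 h (on this read-out lower numbers stand for stronger inhibition and higher numbers for weaker inhibition), compound 3 `O=C(Nc1cccc(-c2ccc(-c3ccccc3)cc2)c1)C(Cl)Cl` gives > 50000 nM, which is a limit and not a number. Compound 2 `COc1ccc(-c2cccc(NC(=O)C(Cl)Cl)c2)cc1` gives > 50000 nM, also a limit. Compound 1 `CSc1cccc(-c2cc(NC(=O)C(Cl)Cl)cc(-c3cccc(SC)c3)c2)c1` gives > 30000 nM, again a limit. Among the measured compounds shown here, no compound so far has a numerical reading, so compound 3 cannot be ranked against the other two.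

The change under review leads to compound 4 `Cc1ccc(-c2cccc(NC(=O)C(Cl)Cl)c2)cc1`: methyl in place of phenyl on an aromatic carbon. In words, this is methyl in place of phenyl on an aromatic carbon, para to a large group. For the measured compounds named here, the one measured step at this place is a step that the two limits leave unreadable from compound 2 to compound 3, and it gives neither a size nor a direction. The expectation therefore rests on the limits themselves. Compound 2 carries methoxy at this place and reads > 50000 nM, a limit. Compound 3 carries phenyl there and reads > 50000 nM, the same limit. With neither group giving a numerical reading, methyl is not expected to behave differently in this assay. The expected step is a number no higher from compound 3 to compound 4 (the limit leaves the size open), and nothing beyond the scatter is estimated. Compound 4 is expected at 50000 nM, with an estimated range of 20000 nM to 100000 nM, and will most likely be reported as a limit again.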

Compound 4, half-maximal inhibitory concentration: > 50000 nM
Compound 4 was reported as a limit; the forecaster's own chance of this, stated with the estimate: 80%; the middle value sits exactly at the limit.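

In this assay compound 4 gives > 50000 nM, which is a limit. Among the compounds shown here, compound 2, compound 3 and compound 4 all stand as limits, so no step among them can be read. The compounds shown leave open whether any group at this place on the shared core gives a numerical reading in this assay.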